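The source may report more compounds than this note shows. Statements on the series, on what has been measured and on what is new or still open speak of the compounds shown alone.

Among the measured compounds shown here, compound 1, with the structure `O=S(=O)(CC1=NCCO1)c1n[nH]cc1-c1ccccc1`, is the only compound in this small set that gives a number. In a functional assay, tested at 75 ug/mL (on this read-out higher numbers stand for a stronger effect at the one concentration tested and lower numbers for a weaker effect), compound 1 gives 55.6%, and that is where it stands: alone, with nothing to rank it against. For the measured compounds named here, its closest relative, compound 2 `O=S(=O)(CC1=NCCS1)c1n[nH]cc1-c1ccccc1`, differs in the five-membered ring on the chain and was reported in this assay as "not active" (no number reported) without a number, so no step between the two can be sized.

Compound 3 `Cc1ccc(-c2c[nH]nc2S(=O)(=O)CC2=NCCO2)cc1` has not yet been measured. It differs from compound 1 by methyl in place of hydrogen on an aromatic carbon, which the change summary also describes as phenyl to 4-methylphenyl. Going by the values given here, with no comparable step measured, the expectation for this assay is a step from compound 1 to compound 3 of a number 0.6 percentage points lower from compound 1 to compound 3 (within the scatter), that is, none beyond the scatter. Compound 3 is therefore estimated at 55%, within 30% to 75%.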

Compound 3, a percentage reported as activity, at one concentration (the size of the read-out at that concentration, not a potency): 62%
Estimate against measurement, compound 3: 7 percentage points below; the range from low to high includes it.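

Placing methyl in place of hydrogen on an aromatic carbon of the six-membered ring, para to a large group, gives a number 6.4 percentage points higher from compound 1 to compound 3 (within the scatter) in this assay. On this read-out compound 1 and compound 3 cannot be told apart, so this first measured change on the phenyl ring shows that this place can carry a methyl and the compound still gives a clear number at the one concentration tested. No other measurement here bears on this result or offers a reason for it.

Open, going by these compounds, is whether a longer chain such as ethyl, an amine or a carboxylic acid would be accepted at this same place. Also open, on these data alone, is whether methyl at this place would give a number when the rest of the molecule is that of compound 2, which has none.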